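Naphthalene in place of methylphenyl on a urotensin-2 agonist series

The source may report more compounds than this note shows. Statements on the series, on what has been measured and on what is new or still open speak of the compounds shown alone.

Of the compounds shown here, two in this set have been measured. Compound 1 `COc1ccc(CCC(=O)NC(CCN(C)C)c2ccc3ccccc3c2)cc1` gives 1410 nM in a functional assay on NIH3T3 cells for agonist activity at Urotensin-2 receptor (Homo sapiens), with a stated time of 5 days; on this read-out lower numbers stand for an effect already at smaller amounts and higher numbers for an effect only at larger amounts of compound. Compound 2 `Cc1ccc(C(CCN(C)C)NC(=O)CCc2ccc(C(F)(F)F)cc2)cc1` gives 2290 nM in this assay, which is the higher of the two numbers, though the gap to compound 1 lies within the scatter of the measurement, so no order between them can be read from it. Compound 3 `CN(C)CCC(NC(=O)CCc1ccc(C(F)(F)F)cc1)c1ccc2ccccc2c1` has not yet been measured. It differs from compound 2 by naphthalen-2-yl in place of 4-methylphenyl on a saturated chain carbon bound to an amide-type nitrogen and a saturated chain carbon, and it carries the same naphthalen-2-yl group that compound 1 bears. Within the data shown here, no step between measured compounds with a single change is available here, so the direction must be judged from the two values alone. Compound 3 is expected to show a small lowering a 1.8-fold lower number from compound 2 to compound 3 (0.25 log units; within the scatter), not clearly beyond the scatter, because compound 1 with the same naphthalene group gives 1410 nM. The estimate for compound 3 is 1300 nM, with a range from 450 nM to 3800 nM.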

Compound 3, half-maximal effective concentration: 372 nM
The estimate for compound 3 lay 3.5-fold (0.54 log units) above the measured number; measured number outside the range, below it.
By their numbers in this assay, from the lowest: compound 3; then compounds 1 and 2 (each within the scatter of the next).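

Naphthalen-2-yl in place of 4-methylphenyl on a saturated chain carbon bound to an amide-type nitrogen and a saturated chain carbon gives a 6.2-fold lower number from compound 2 to compound 3 (0.79 log units; beyond the scatter) in this assay, so this position responds to the change by more than the scatter when trifluoromethyl is held fixed. With naphthalen-2-yl held fixed, trifluoromethyl in place of methoxy on an aromatic carbon gives a 3.8-fold lower number from compound 1 to compound 3 (0.58 log units; beyond the scatter), which shows that the group on the other aromatic ring also counts, something the two earlier values alone could not reveal. Nothing given here accounts for either step.

Going by these compounds, it remains open whether naphthalen-2-yl would give a comparable step alongside a chlorine or a nitrile in place of trifluoromethyl. On these data alone, what a primary amine or a longer chain would do on the shared core also remains open.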